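This account rests on a few compounds, and the source may have more. Where it says the series, first, only, none or still open, it means among the compounds named here.

Measured so far in an assay on isolated protein for inhibition of Amine oxidase [flavin-containing] B (Homo sapiens), read by fluorescence, with stated times of 15 min and 20 min; a higher number here means a weaker inhibitor, a lower number a stronger inhibitor:
compound 1, `CC(C)(C)c1cc(C(=O)NC2CCN(Cc3ccccc3)CC2)cc(C(C)(C)C)c1O` — 85100 nM
compound 2, `CC(C)(C)c1cc(C(=O)NCCC2CCN(Cc3ccccc3)CC2)cc(C(C)(C)C)c1O` — 89200 nM
compound 3, `CC(C)(C)c1cc(/C=C/C(=O)NCCC2CCN(Cc3ccccc3)CC2)cc(C(C)(C)C)c1O` — 8500 nM

Among these three, compound 3 gives the lowest number in this assay, and both its neighbours lie well beyond the scatter above it: compound 1 with 85100 nM and compound 2 with 89200 nM. Compound 3 is thus the strongest inhibitor of the set. Among the measured compounds shown here, no pairwise step is counted between the measured compounds, since each pair differs in more than one place, so only the values themselves can be compared.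

Compound 4, `CC(C)(C)c1cc(/C=C/C(=O)NCCC2CCN(Cc3cccc(Cl)c3)CC2)cc(C(C)(C)C)c1O`, is not yet measured. Its structural change from compound 3 is chloro in place of hydrogen on an aromatic carbon: a chloro enters on an aromatic carbon of a six-membered aromatic ring of carbon only, turning the benzyl into a 3-chlorobenzyl. No comparable change is measured in this set, so the size and direction of the step are not given by the data. A modest step, most likely toward a lower number or none beyond the scatter, is expected for compound 4, as a 1.4-fold lower number from compound 3 to compound 4 (0.15 log units; within the scatter). The estimate for compound 4 in this assay is 6000 nM, with a range from 2500 nM to 15000 nM.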

Compound 4, half-maximal inhibitory concentration: 8700 nM
Estimate against measurement, compound 4: 1.5-fold (0.16 log units) below; low and high end bracket the measured number.
By their numbers in this assay, from the lowest: compounds 3 and 4 (each within the scatter of the next); then compounds 1 and 2 (each within the scatter of the next).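

In this assay, among the compounds shown here, chloro in place of hydrogen on an aromatic carbon gives a 1.0-fold higher number from compound 3 to compound 4 (0.01 log units; within the scatter), the only step that changes a single place. The earlier compounds shown here gave no reading of the benzyl ring at all, whereas this pair shows that a 3-chlorobenzyl, with its chloro meta to a large group, keeps the number of the benzyl within the scatter. No available evidence bears on why the chloro leaves the two values indistinguishable.

From the compounds shown here alone, whether a different group at this place, such as fluoro, methoxy or a nitrile, would move the number remains open. So does whether a chloro on another carbon of the same ring would read the same way.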